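The source may hold more compounds than are shown below. What is called first, only, known or untested is meant among the compounds shown, and "the series" means these compounds.

Measured compounds:
- compound 1 `CC(C)OC(=O)[C@H](C)NC(=O)c1ccc(Nc2nc(Cl)nc(Cl)n2)cc1`: 3.02%
- compound 2 `O=c1nc(SCc2ccccc2)nc(SCc2ccccc2F)[nH]1`: "not determined" (no result reported)
- compound 3 `O=c1nc(SCc2ccccc2)nc(SCc2ccccc2[N+](=O)[O-])[nH]1`: "not determined" (no result reported)

The study concerns an assay for inhibition of Pro-cathepsin H (Homo sapiens), read by fluorescence, tested at 50 uM; a higher number here means more inhibition at the concentration tested (going by the name of the read-out), a lower number less inhibition. For the measured compounds named here, only one compound has a number in this assay: compound 1 gives 3.02%, a low reading. Compound 2 stands without a single number in this assay, where it gives "not determined" (no result reported). Going by the values given here, compound 3 is in the same position, with "not determined" (no result reported) in this assay, so the two benzyl-sulfide members of the set give no point of comparison, and the only number in hand comes from compound 1, which is built on a different core.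

The piece follows the step from compound 2 to compound 4 `CCSc1nc(SCc2ccccc2)nc(=O)[nH]1`. The change is methyl in place of 2-fluorophenyl on a saturated chain carbon bound to a sulfur. Among the compounds with values here, with no step between measured compounds to draw on, and with compound 2 itself lacking a number, no direction can be read from the data for this change; the account expects a small step at most, not beyond the usual scatter, and a reading in the low region that compound 1 occupies in this assay.

Compound 4 is therefore expected to give about 5% in this assay, with a plausible range from -10% to 25%.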

Compound 4, a percentage reported as inhibition, at one concentration (the size of the read-out at that concentration, not a potency): -4.06%
For compound 4 the middle estimate is 9.1 percentage points above the measured one; low and high end bracket the measured number.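

In this assay compound 4 gives -4.06% while compound 2 gives "not determined" (no result reported) and so no step can be read between the two. The compounds shown leave open whether exchanging 2-fluorobenzyl for ethyl moves this inhibition reading at all. No evidence bearing on this result is at hand.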